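Bromo for methyl on the benzyl ring

The compounds below may be only part of what the source reports. "The series", "measured", "known", "first", "only" and "open" are said of these compounds alone.

Compound 1, `Cn1ccc2nccc(NC(=O)NCCN3CCC(O)(Cc4ccccc4)CC3)c21`: 600 nM
Compound 2, `CCc1cc(NC(=O)NCCN2CCC(O)(Cc3ccccc3)CC2)c2sccc2n1`: 60 nM
Compound 3, `Cc1cccc(CC2(O)CCN(CCNC(=O)Nc3ccnc4ccsc34)CC2)c1`: 140 nM

In an assay on HEK293 cells for displacement of a labelled ligand from Urotensin-2 receptor (Homo sapiens) (on this read-out lower numbers stand for stronger inhibition and higher numbers for weaker inhibition), compound 3 gives 140 nM, the second highest of the three numbers. Compound 2 gives 60 nM, a lower number beyond the scatter, and compound 1 gives 600 nM, a higher number beyond the scatter. Compound 4, `O=C(NCCN1CCC(O)(Cc2cccc(Br)c2)CC1)Nc1ccnc2ccsc12`, differs from compound 3 in one place: bromo in place of methyl on an aromatic carbon. Within the data shown here, no pair of measured compounds shows this exchange, so nothing here tells how large its effect is. The step from compound 3 to compound 4 in this assay is expected to be small, with no clear direction and likely within the scatter, as a 1.2-fold lower number from compound 3 to compound 4 (0.07 log units; within the scatter). Compound 4 is therefore estimated at 120 nM, with a range from 45 nM to 320 nM.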

Compound 4, half-maximal inhibitory concentration: 42 nM
For compound 4 the middle estimate is 2.9-fold (0.46 log units) above the measured one; the whole stated range lies above it.
By their numbers in this assay, from the lowest: compounds 4 and 2 (each within the scatter of the next); then compound 3; then compound 1.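

In this assay, bromo in place of methyl on the benzyl ring gives a 3.3-fold lower number from compound 3 to compound 4 (0.52 log units; beyond the scatter), a step beyond the scatter. This is the first change in a single place among these compounds, and it shows that this aromatic carbon responds to the exchange of one heavy atom for another. Nothing available accounts for the step.

On these data alone, whether chloro, methoxy or an amine at this position would go further remains open. So does whether the same exchange would carry over to the cores of compound 1 and compound 2.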